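A few compounds are considered here, and "the series" means these few. Any claim that something is new, unique, unknown or untested is made for them only; others in the source may bear on it.

Compound 1 `N#Cc1ccc(COC[C@H]2O[C@@H](n3c(NCc4ccc(Cl)c(Cl)c4)nc4c(N)ncnc43)[C@H](O)[C@@H]2O)cc1` gives 5000 nM in a functional assay on HCT-116 cells (Homo sapiens) for cytotoxicity, read by sulforhodamine B assay; a lower number here means a stronger inhibitor of growth, a higher number a weaker inhibitor of growth.
Compound 2 `Nc1ncnc2c1nc(NCc1ccc3ncccc3c1)n2[C@@H]1O[C@H](COCc2ccc(C(F)(F)F)cc2)[C@@H](O)[C@H]1O` gives 27000 nM in this assay.
Compound 3 `N#Cc1ccc(COC[C@H]2O[C@@H](n3c(NCc4ccccc4)nc4c(N)ncnc43)[C@H](O)[C@@H]2O)cc1` is reported in this assay only as a limit, > 80000 nM.

All three compounds share a core and differ in the groups hung from it. Among the two measured numbers, compound 1 has the lowest; compound 2 sits at a higher number, a gap beyond the usual scatter. For compound 3 the assay reports only a limit of > 80000 nM in this assay, at which 1 of the 3 values shown sits, and no number. For the measured compounds named here, the one measured step, an at least 16-fold higher number from compound 1 to compound 3 (1.20 log units; beyond the scatter), comes from replacing 3,4-dichlorophenyl with phenyl on the saturated chain carbon bound to a nitrogen on an aromatic ring, a large loss in this assay.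

Compound 4 `Nc1ncnc2c1nc(NCc1ccc(Cl)c(Cl)c1)n2[C@@H]1O[C@H](CO)[C@@H](O)[C@H]1O` differs from compound 1 at a different place: hydrogen in place of 4-cyanobenzyl on an oxygen on a saturated carbon. The measured step touches a different part of the molecule, so no measured comparison bears directly on this change. Going by the values given here, the only guide is that trimming a group elsewhere on compound 1 already cost a large amount of activity, and here a whole 4-cyanobenzyl group is removed. A rise in the number, towards weaker growth inhibition, is therefore expected, of about an 8.0-fold higher number from compound 1 to compound 4 (0.90 log units; beyond the scatter). Compound 4 is estimated at 40000 nM, with a range from 8000 nM to 80000 nM.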

Compound 4, concentration for 50% growth inhibition: 26000 nM
Compound 4: middle estimate off by 1.5-fold (0.19 log units), on the high side; low and high end bracket the measured number.
By their numbers in this assay, from the lowest: compound 1; then compounds 4 and 2 (each within the scatter of the next). At a limit, above all of these: compound 3.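

Putting hydrogen in place of 4-cyanobenzyl on this oxygen gives a 5.2-fold higher number from compound 1 to compound 4 (0.72 log units; beyond the scatter), so the group on this oxygen does affect growth inhibition in this assay, yet compound 4 keeps a measured number without it. For the compounds shown here, the only earlier change made to compound 1 at a single place gave compound 3, which is reported only as a limit, > 80000 nM. Going by these compounds alone, this is therefore the first single change to compound 1 whose size can be stated as a number. The compounds shown give no measurement that explains why removing the 4-cyanobenzyl group raises the number.

On these data alone, it remains open which part of 4-cyanobenzyl matters: a plain benzyl group on the same oxygen would test whether the nitrile counts, and a methyl group would test whether the aromatic ring counts at all. As far as these compounds go, it is also open whether the size of this step holds with other groups on the nitrogen-bound chain carbon, for example with a pair of compounds that carry phenyl in place of 3,4-dichlorophenyl and differ only at this oxygen.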